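A few compounds are considered here, and "the series" means these few. Any claim that something is new, unique, unknown or untested is made for them only; others in the source may bear on it.

In a functional assay on HT-29 cells (Homo sapiens) for antiproliferative activity, read by sulforhodamine B assay, with a stated time of 48 h (on this read-out higher numbers stand for weaker inhibition and lower numbers for stronger inhibition), compound 1 `O=C(NCCCNc1cc(-c2cn(-c3ccccc3)nc2-c2cccc(O)c2)ccn1)Nc1ccc(F)cc1` gives 1090 nM and compound 2 `O=C(NCCCNc1cc(-c2cn(-c3ccccc3)nc2-c2cccc(O)c2)ccn1)Nc1cccc(C(F)(F)F)c1` gives 1510 nM. These two numbers lie within the scatter of each other, so compound 1 cannot be ranked apart from compound 2. Compound 3 `COc1cccc(-c2nn(-c3ccccc3)cc2-c2ccnc(NCCCNC(=O)Nc3ccc(F)cc3)c2)c1` differs from compound 1 in one place: methyl in place of hydrogen on an oxygen on an aromatic ring. That is methyl in place of hydrogen on an oxygen on an aromatic ring, which turns 3-hydroxyphenyl into 3-methoxyphenyl. Among the measured compounds shown here, the only measured step, a 1.4-fold higher number from compound 1 to compound 2 (0.14 log units; within the scatter), concerns a different change, on an amide-type nitrogen, and leaves the hydroxy group untouched. For the measured compounds named here, it therefore gives no direct guide, and no measured compound carries the methoxy group. A step within the scatter is expected in this assay, if anything toward a higher number. The estimated step is a 1.7-fold higher number from compound 1 to compound 3 (0.22 log units; within the scatter). For compound 3 the expected value is 1800 nM, with an estimated range from 700 nM to 5000 nM.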

Compound 3, half-maximal inhibitory concentration: 7170 nM
For compound 3 the middle estimate is 4.0-fold (0.60 log units) below the measured one, outside the stated range (above it).
By their numbers in this assay, from the lowest: compounds 1 and 2 (each within the scatter of the next); then compound 3.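

Turning the hydroxy group into a methoxy group counts in this assay: there is a 6.6-fold higher number from compound 1 to compound 3 (0.82 log units; beyond the scatter), a step beyond the scatter. Among the compounds shown here, the one earlier step, a 1.4-fold higher number from compound 1 to compound 2 (0.14 log units; within the scatter), was a change on an amide-type nitrogen and stayed within the scatter, so this is the first sign that a single added methyl on this oxygen, with its hydrogen leaving, can shift the number measurably. Nothing available here explains why the number rises with this change.

The compounds shown leave open whether an amine or a carboxylic acid in place of the hydroxy group would keep the number near that of compound 1, and whether a longer ether such as ethoxy would raise it further. Also open, on these data alone, is whether the same methyl gives a similar step alongside the 3-(trifluoromethyl)phenyl group of compound 2.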